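Fluoro to trifluoromethyl on two cores, cytotoxicity notes

The compounds below may be only part of what the source reports. "The series", "measured", "known", "first", "only" and "open" are said of these compounds alone.

Compound 1 `CC(=O)Nc1ccc(O)c(C(=O)/C=C/c2ccc(F)cc2)c1` and compound 2 `CC(=O)Nc1ccc(O)c(C(=O)/C=C/c2ccc(C(F)(F)F)cc2)c1` share one core; compound 3 `CC(=O)Nc1ccc2oc(-c3cccc(F)c3)cc(=O)c2c1` and the still unmeasured compound 4 `CC(=O)Nc1ccc2oc(-c3cccc(C(F)(F)F)c3)cc(=O)c2c1` share another. The difference between the two cores is not broken down here.

In an ADME assay on THP-1 cells (Homo sapiens) for cytotoxicity, read by flow cytometry and propidium iodide staining, with a stated time of 72 h (a higher number here means a weaker inhibitor, a lower number a stronger inhibitor), compound 1 gives 68800 nM. In this assay compound 2 gives 15500 nM. The change between them is trifluoromethyl in place of fluoro on an aromatic carbon, and the step it made is a 4.4-fold lower number from compound 1 to compound 2 (0.65 log units; beyond the scatter).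

For compound 3 only a limit is known: in this assay compound 3 gives > 125000 nM, which is a limit of the assay and not a number, namely (the limit of > 125000 nM in this assay, at which 1 of the 3 values shown sits).

Compound 4 differs from compound 3 by trifluoromethyl in place of fluoro on an aromatic carbon. This is the same kind of change as that from compound 1 to compound 2, not the same one: in compound 2 the trifluoromethyl sits para to a large group, in compound 4 meta to a large group.

The step from compound 3 to compound 4 is expected to be an at least 2.0-fold lower number from compound 3 to compound 4 (0.31 log units; beyond the scatter), resting on the measured step of a 4.4-fold lower number from compound 1 to compound 2 (0.65 log units; beyond the scatter), with the range kept wide since the starting point for compound 3 is a limit rather than a number and the placing of the group differs. In this assay compound 4 is expected to give 60000 nM, between 20000 nM and 125000 nM.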

Compound 4, half-maximal inhibitory concentration: 50000 nM
The estimate for compound 4 lay 1.2-fold (0.08 log units) above the measured number, and the stated range covers the measured number.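

In this assay, trifluoromethyl in place of fluoro on an aromatic carbon gives an at least 2.5-fold lower number from compound 3 to compound 4 (0.39 log units; beyond the scatter), so the number falls on the core of compound 3 as it does on the core of compound 1. Set side by side, the two steps point the same way, but their sizes cannot be separated: the same change on two cores in this assay, a 4.4-fold lower number (0.65 log units; beyond the scatter) from compound 1 to compound 2 and an at least 2.5-fold lower number (0.39 log units; beyond the scatter) from compound 3 to compound 4; the limit leaves it open whether they differ. Going by these compounds, for compound 3 the assay gives > 125000 nM, which is a limit and not a number, so the true size of the step on this core stays unknown; the carry-over therefore shows a shared direction across just these two pairs, not a shared size, and it is further limited by the trifluoromethyl in compound 4 sitting meta to a large group, a placing not shared with compound 2.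

The compounds shown carry only fluoro or trifluoromethyl at the changed place, so it remains open whether the same direction would hold with a chlorine, a nitrile or an amine there. Each core also appears with only one placing of the changed group, which leaves open how much of any difference in step size would belong to the core and how much to the placing.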